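The source may report more compounds than this note shows. Statements on the series, on what has been measured and on what is new or still open speak of the compounds shown alone.

Compound 1 `COc1ccc(S(C)(=O)=O)c(NCC2=NCCN2)c1` carries a methylsulfonyl group and a methoxy group on the shared core. Within the data shown here, in an assay for binding affinity to Alpha-1A adrenergic receptor (Homo sapiens), read by radioligand binding (a lower number here means a stronger inhibitor, a higher number a weaker inhibitor), compound 1 gives 1620 nM, the highest of the three numbers measured so far. Compound 3 `COc1ccc(SC)c(NCC2=NCCN2)c1`, the methylsulfanyl analogue with methoxy retained, gives 174 nM in this assay, and compound 2 `CSc1cc(F)ccc1NCC1=NCCN1`, with methylsulfanyl and fluoro, gives 20.9 nM. Among the measured compounds shown here, the only single-point step among the measured compounds is a 9.3-fold lower number from compound 1 to compound 3 (0.97 log units; beyond the scatter), methylsulfanyl in place of methylsulfonyl.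

Compound 4 `CS(=O)(=O)c1ccc(Cl)cc1NCC1=NCCN1` keeps the methylsulfonyl group of compound 1 and changes (chloro in place of methoxy on an aromatic carbon). For the measured compounds named here, no measured step exchanges methoxy for a halogen directly. The nearest comparison is between compound 3 and compound 2, where methoxy gives way to fluoro while methylsulfanyl is kept: compound 3 shows 174 nM, whereas compound 2 shows 20.9 nM, the lower number. Chloro is not fluoro, and the exchange here takes place on a methylsulfonyl-bearing core rather than a methylsulfanyl one, so the transfer is uncertain. Still, the expected direction is toward a lower number, and the step from compound 1 to compound 4 is estimated as a 6.5-fold lower number from compound 1 to compound 4 (0.81 log units; beyond the scatter). Compound 4 is therefore expected at 250 nM in this assay, with a range from 60 nM to 1000 nM.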

Compound 4, inhibition constant: 537 nM
The estimate for compound 4 lay 2.1-fold (0.33 log units) below the measured number; measured number inside the range.
By their numbers in this assay, from the lowest: compound 2; then compound 3; then compound 4; then compound 1.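

In this assay, the position para to a methylsulfonyl group now has a single-place step of its own: chloro in place of methoxy gives a 3.0-fold lower number from compound 1 to compound 4 (0.48 log units; beyond the scatter). Among these compounds, until now the only such step was at the sulfur-bearing group, a 9.3-fold lower number from compound 1 to compound 3 (0.97 log units; beyond the scatter), so the number is now seen to move at this second position too, with the methylsulfonyl group left unchanged. No supporting data on the compounds bear on why the exchange of methoxy for chloro lowers the number.

The compounds shown leave open whether chloro in place of methoxy gives a step of similar size on the methylsulfanyl-bearing core of compound 3, and whether fluoro on the methylsulfonyl-bearing core of compound 1 would behave as chloro does. Among the compounds shown here, they also leave open how this position responds to groups of other kinds, such as an amine, a nitrile or a longer alkoxy chain, so the step so far describes one exchange and not a trend across substituents.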